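Changing two stereo elements of compound 3

This account rests on a few compounds, and the source may have more. Where it says the series, first, only, none or still open, it means among the compounds named here.

Measured so far in an ADME assay on HFF cells (Homo sapiens) for cytotoxicity, read by neutral red uptake; a lower number here means that less compound is tolerated, a higher number that more compound is tolerated:
- compound 1 `Nc1ncnc2c1ncn2/C=C1/C[C@H]1[C@H](O)CO` gives 206000 nM
- compound 2 `Nc1ncnc2c1ncn2/C=C1\C[C@H]1[C@H](O)CO` gives 194000 nM
- compound 3 `Nc1ncnc2c1ncn2/C=C1/C[C@@H]1[C@H](O)CO` gives > 300000 nM

Compound 3 gives > 300000 nM, and this is a limit of the assay, not a number.

Compound 4 `Nc1ncnc2c1ncn2/C=C1\C[C@@H]1[C@@H](O)CO` has the same atoms and bonds as compound 3, and the change is the two compounds have the same atoms and bonds and differ only in configuration as drawn: 2 of 3 stereo elements differ; a stereocentre at a saturated chain carbon is drawn S in compound 3 and R in compound 4; a double bond is drawn Z in compound 3 and E in compound 4: a stereocentre at a saturated chain carbon is drawn S in compound 3 and R in compound 4, and a double bond is drawn Z in compound 3 and E in compound 4.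

The double bond change alone was measured as a 1.1-fold lower number from compound 1 to compound 2 (0.03 log units; within the scatter). Two further steps involve the ring stereocentre, an at least 1.4-fold higher number from compound 1 to compound 3 (0.16 log units; that floor lies within the scatter) and an at least 1.5-fold higher number from compound 2 to compound 3 (0.18 log units; that floor lies within the scatter), and each is only a floor. Going by the values given here, none of the measured compounds varies the chain stereocentre, so that part of the change is untested. No step beyond the scatter is therefore expected in this assay.

The expected step is an at least 1.1-fold lower number from compound 3 to compound 4 (0.06 log units; that floor lies within the scatter).

For compound 4 the estimate is 260000 nM, with an expected range from 140000 nM to 450000 nM.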

Compound 4, half-maximal cytotoxic concentration: > 300000 nM
Compound 4 ended at the assay's limit (the forecaster's own chance of this, stated with the estimate: 40%); middle value at least 1.1-fold (0.06 log units) away from the limit.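

In this assay compound 4 joins compound 3 at the limit, which is not a number, so the step between these two compounds cannot be read: the limit of > 300000 nM in this assay, at which 2 of the 4 values shown sit.

The new point is that the chain stereocentre drawn R, together with the double bond drawn E and the ring stereocentre drawn S, still reaches this limit. The result gives an at least 1.5-fold higher number from compound 2 to compound 4 (0.18 log units; that floor lies within the scatter) and an at least 1.4-fold higher number from compound 1 to compound 4 (0.16 log units; that floor lies within the scatter), so both compounds with the ring stereocentre drawn S sit at the limit, yet neither floor goes beyond the scatter.

As far as these compounds go, what the chain stereocentre does on its own stays open, as do the true values of compound 3 and compound 4 beyond the limit. Also open, from the compounds shown here alone, is whether this tolerance would hold with an amine or a carboxylic acid in place of a hydroxyl group.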